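Sulfonamide Series Tested for Antiproliferative Effect

The compounds below may be only part of what the source reports. "The series", "measured", "known", "first", "only" and "open" are said of these compounds alone.

Measured so far in a functional assay on M21 cells (Homo sapiens) for antiproliferative activity, read by sulforhodamine B assay, with a stated time of 48 h; on this read-out higher numbers stand for weaker inhibition and lower numbers for stronger inhibition:
Compound 1, `COc1ccccc1NS(=O)(=O)c1ccc(N2CCNC2=O)cc1`, gives 300 nM.
Compound 2, `O=C1NCCN1c1ccc(S(=O)(=O)Nc2ccc(Br)cc2)cc1`, gives 130 nM.
Compound 3, `COc1cccc(NS(=O)(=O)c2ccc(N3CCNC3=O)cc2)c1`, gives 65 nM.

Compound 3 stands at the lowest of the three numbers shown. Its gap to compound 1, a 4.6-fold lower number from compound 1 to compound 3 (0.66 log units; beyond the scatter), is beyond the scatter, whereas its gap to compound 2, a 2.0-fold lower number from compound 2 to compound 3 (0.30 log units; within the scatter), is within it, so compound 2 and compound 3 cannot be ranked against each other on these data.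

Compound 4, `Cc1cccc(NS(=O)(=O)c2ccc(N3CCNC3=O)cc2)c1C`, has not been measured. Relative to compound 3 the change is 2,3-dimethylphenyl in place of 3-methoxyphenyl on a sulfonamide nitrogen. Going by the values given here, no measured step exchanges a methoxy group for methyl groups, so the only guides are the two steps that vary the same aryl group on the sulfonamide nitrogen, a 4.6-fold lower number from compound 1 to compound 3 (0.66 log units; beyond the scatter) and a 2.0-fold lower number from compound 2 to compound 3 (0.30 log units; within the scatter). They show that varying this group moves the number by modest amounts only. The entering 2,3-dimethylphenyl carries no hydrogen-bond acceptor where 3-methoxyphenyl carried one, and compound 1, bearing 2-methoxyphenyl, gave the highest number, which counsels some caution. Compound 4 is therefore expected to give a somewhat higher number, a step of a 1.7-fold higher number from compound 3 to compound 4 (0.23 log units; within the scatter), estimated at 110 nM with a range from 40 nM to 350 nM.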

Compound 4, half-maximal inhibitory concentration: 110 nM
Beside the measured number, compound 4's estimate shows no gap at the digits printed; low and high end bracket the measured number.
By their numbers in this assay, from the lowest: compounds 3, 4 and 2 (each within the scatter of the next); then compound 1.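

In this assay, the oxygen of 3-methoxyphenyl can give way to the two methyl groups of 2,3-dimethylphenyl on the sulfonamide nitrogen without a readable change, as a 1.7-fold higher number from compound 3 to compound 4 (0.23 log units; within the scatter) and a 1.2-fold lower number from compound 2 to compound 4 (0.07 log units; within the scatter) show, so compound 2, compound 3 and compound 4 form one group that these data cannot rank, and a hydrogen-bond acceptor on this ring is not needed to stay within it. Compound 1 remains apart, with a 2.7-fold lower number from compound 1 to compound 4 (0.44 log units; beyond the scatter), so the higher number seen with 2-methoxyphenyl does not carry over to every group whose name includes a 2, since 2,3-dimethylphenyl, which also does, sits with the lower set. Nothing available here gives a measured reason for these numbers.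

On these data alone, whether one methyl group would be enough, as in 3-methylphenyl or 2-methylphenyl, remains open, because the two methyl groups of compound 4 enter together and cannot be judged separately. Also open, as far as these compounds go, is how far this position tolerates other kinds of group, such as an aminophenyl ring, a carboxyphenyl ring, a pyridyl ring or a cyclohexyl ring in place of the aromatic carbon rings seen so far.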